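Hydrazone aryl variation: estimate for trimethoxyphenyl analogue

The compounds below may be only part of what the source reports. "The series", "measured", "known", "first", "only" and "open" are said of these compounds alone.

The series shares one core and varies the aryl group on the carbon with a double bond to nitrogen. Compound 1 `CN(C)CCn1cnnc1-c1cc(Oc2ccc(NC(=O)N/N=C/c3cccc(O)c3)cc2F)ccn1` carries 3-hydroxyphenyl, compound 2 `CN(C)CCn1cnnc1-c1cc(Oc2ccc(NC(=O)N/N=C/c3cc(C(C)(C)C)cc(C(C)(C)C)c3O)cc2F)ccn1` carries the di-tert-butyl hydroxyphenyl, and compound 3 `CN(C)CCn1cnnc1-c1cc(Oc2ccc(NC(=O)N/N=C/c3cc(Br)c(O)c(Br)c3)cc2F)ccn1` carries 3,5-dibromo-4-hydroxyphenyl. Within the data shown here, in a functional assay on NCI-H460 cells (Homo sapiens) for cytotoxicity, read by MTT assay, with a stated time of 72 h (a lower number here means a stronger inhibitor, a higher number a weaker inhibitor), compound 1 gives 780 nM, compound 2 gives 590 nM, and compound 3 gives 3760 nM, the highest of the three numbers; the one measured step reaching it is a 4.8-fold higher number from compound 1 to compound 3 (0.68 log units; beyond the scatter).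

Compound 4 `COc1ccc(/C=N/NC(=O)Nc2ccc(Oc3ccnc(-c4nncn4CCN(C)C)c3)c(F)c2)c(OC)c1OC` is the next analogue, differing from compound 3 as follows: 2,3,4-trimethoxyphenyl in place of 3,5-dibromo-4-hydroxyphenyl on a carbon with a double bond to nitrogen. Among the measured compounds shown here, no measured step involves a 2,3,4-trimethoxyphenyl group, so nothing bears directly on this change; the only step on the same carbon, a 4.8-fold higher number from compound 1 to compound 3 (0.68 log units; beyond the scatter), shows that exchanging the aryl group here can move the number by a modest amount in either direction, and compounds 1 and 2 lie well below compound 3. The expected outcome is a somewhat lower number than compound 3, with wide uncertainty, that is a 2.5-fold lower number from compound 3 to compound 4 (0.40 log units; beyond the scatter).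

Compound 4 is therefore estimated at 1500 nM in this assay , with a range from 400 nM to 6000 nM.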

Compound 4, half-maximal inhibitory concentration: 1790 nM
Compound 4: the middle estimate sits 1.2-fold (0.08 log units) below what was measured, within the range that was stated.
By their numbers in this assay, from the lowest: compounds 2 and 1 (each within the scatter of the next); then compound 4; then compound 3.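

In this assay, the 2,3,4-trimethoxyphenyl group gives a 2.1-fold lower number from compound 3 to compound 4 (0.32 log units; beyond the scatter), yet also a 2.3-fold higher number from compound 1 to compound 4 (0.36 log units; beyond the scatter), so an aryl group carrying 0 hydrogen-bond donors lands between the two hydroxyphenyl compounds, with both steps beyond the scatter. A hydroxyl on the aryl group therefore does not by itself set the order at this carbon: among the listed compounds, compound 1 and compound 3 both carry one and lie on opposite sides of compound 4, so the presence or absence of that group fails as a simple rule. No measured information on the compounds accounts for these differences in the cell read-out.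

The compounds shown do not separate the loss of the two bromines from the loss or shift of the hydroxyl in the change from 3,5-dibromo-4-hydroxyphenyl to 2,3,4-trimethoxyphenyl, nor do they show which of the three methoxy groups matters. Going by these compounds, how an aryl group bearing an amine or a carboxylic acid on this carbon would compare also remains open.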